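The compounds below may be only part of what the source reports. "The series", "measured", "known", "first", "only" and "open" are said of these compounds alone.

The study centres on compound 1 `CC1CCC(C(=O)N2CC(c3nc(-c4cccc(Cl)c4)no3)C2)CC1`, which in an assay on HEK293 cells for negative allosteric modulation of metabotropic glutamate receptor 5 (Homo sapiens), read by FLIPR (a higher number here means a weaker inhibitor, a lower number a stronger inhibitor), is known only as a limit, compound 1 giving > 10000 nM. Compound 1 therefore cannot be placed among its neighbours by a number; it sits at the limit of > 10000 nM in this assay, at which 2 of the 3 values shown sit, alongside one other compound. Compound 3 `O=C(c1ccc(F)c(F)c1)N1CC(c2nc(-c3cccc(F)c3)no2)C1` shares that fate, its reading in this assay being a limit, compound 3 giving > 10000 nM. Going by the values given here, the one compound with a measured value is compound 2 `Cc1cccc(S(=O)(=O)N2CC(c3nc(-c4cccc(Cl)c4)no3)C2)c1`, which in this assay gives 390 nM. Among the compounds with values here, no single-point step between these three is available, so their values can only be set side by side: the two carbonyl-linked compounds return limits, while the sulfonyl-linked compound 2 returns a number.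

Compound 4 `CC1CCN(C(=O)N2CC(c3nc(-c4cccc(Cl)c4)no3)C2)C1` is the compound still to be measured. It differs from compound 1 by 3-methylpyrrolidin-1-yl in place of 4-methylcyclohexyl on a carbonyl carbon, so the carbonyl now carries a ring nitrogen instead of a ring carbon. Within the data shown here, both compound 1 and compound 3 carry a carbonyl on the ring nitrogen of the shared core and both stand at the limit, and nothing among the measured compounds shows a carbonyl-linked member leaving it. The step from compound 1 to compound 4 is therefore expected to be none beyond the scatter, a step that the limit leaves unreadable from compound 1 to compound 4. In this assay compound 4 is expected to give about 15000 nM, within a range of 4000 nM to 50000 nM, with a limit the likely outcome.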

Compound 4, half-maximal inhibitory concentration: > 10000 nM
Compound 4 gave a limit, no number; the forecaster's own chance of this, stated with the estimate: 70%; the middle value lies beyond the limit too.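

In this assay compound 4 gives > 10000 nM, a limit and not a number. Going by these compounds alone, as compound 1 also stands at a limit, no step from compound 1 to compound 4 can be read. The compounds shown leave open whether 3-methylpyrrolidin-1-yl and 4-methylcyclohexyl on the carbonyl carbon differ at all in this assay.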